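The source may hold more compounds than are shown below. What is called first, only, known or untested is meant among the compounds shown, and "the series" means these compounds.

In an assay on CHO-K1 cells for inhibition of 11-beta-hydroxysteroid dehydrogenase type 2 (Mus musculus), read by scintillation proximity assay (a higher number here means a weaker inhibitor, a lower number a stronger inhibitor), compound 2 `CCSCCC12CCC(c3nnc(-c4ccccc4C(F)(F)F)n3C)(CC1)CC2` gives > 4000 nM, which is a limit of the assay rather than a number. Compound 1 `CCOCC12CCC(c3nnc(-c4ccccc4C(F)(F)F)n3C)(CC1)CC2` likewise gives only a limit, > 4000 nM. The step that the two limits leave unreadable from compound 1 to compound 2 therefore cannot be read, since both values sit at the limit of > 4000 nM in this assay, at which 2 of the 2 values shown sit. Compound 3 `CC(C)S(=O)(=O)CCC12CCC(c3nnc(-c4ccccc4C(F)(F)F)n3C)(CC1)CC2` differs from compound 2 by isopropylsulfonyl in place of ethylsulfanyl on a saturated chain carbon, two bonds along the chain from a saturated ring carbon. No measured step shows how this change acts in this assay, and the single step shown is itself unreadable, so no direction can be drawn. Compound 3 is therefore expected to give 6000 nM, within 2000 nM to 20000 nM, an expected step that the limit leaves unreadable from compound 2 to compound 3 that most likely again ends at the limit.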

Compound 3, half-maximal inhibitory concentration: > 4000 nM
Compound 3: no number, only a limit; the forecaster's own chance of this, stated with the estimate: 75%; the middle value does not contradict the limit.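

No step among compound 1, compound 2 and compound 3 can be read, since each value is a limit rather than a number: the limit of > 4000 nM in this assay, at which 3 of the 3 values shown sit.

The compounds shown leave open how strongly each one inhibits, and whether changing the group on the chain makes any difference.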